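A few compounds are considered here, and "the series" means these few. Any claim that something is new, unique, unknown or untested is made for them only; others in the source may bear on it.

Compound 1 `COCCCNc1nccc(-c2c(C)[nH]c3ccccc23)n1` in an assay on isolated protein for inhibition of interferon-induced, double-stranded RNA-activated protein kinase (Homo sapiens), read by luminescence, with a stated time of 10 min (on this read-out higher numbers stand for weaker inhibition and lower numbers for stronger inhibition), gives 1500 nM.
Compound 2 `Cc1[nH]c2ccccc2c1-c1ccnc(N2CCCC2)n1` in this assay is reported only as a limit, > 100000 nM.

Compound 2 therefore stands at the edge of what this assay reports, (the limit of > 100000 nM in this assay, at which 1 of the 2 values shown sits), and its position on the numbers is known only as a bound, not as a value. Going by the values given here, the one measured step, an at least 66-fold higher number from compound 1 to compound 2 (1.82 log units; beyond the scatter), ran into that limit when pyrrolidin-1-yl replaced (3-methoxypropyl)amino on an aromatic carbon.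

Compound 3 `Cc1[nH]c2ccccc2c1-c1ccnc(Nc2ccccc2Cl)n1` is not yet measured. It differs from compound 2 by (2-chlorophenyl)amino in place of pyrrolidin-1-yl on an aromatic carbon; the entering (2-chlorophenyl)amino restores the hydrogen-bond donor that pyrrolidin-1-yl lacks. Among the compounds with values here, only the step of an at least 66-fold higher number from compound 1 to compound 2 (1.82 log units; beyond the scatter) bears on this change, and it points the other way: the donor-bearing group gave a numeric value, the donor-free group only a limit. A large step toward lower numbers in this assay is therefore expected, back at least into the region where compound 1 sits. The estimate for compound 3 in this assay is 1000 nM, with a range of 150 nM to 20000 nM. The expected step is an at least 100-fold lower number from compound 2 to compound 3 (2.00 log units; beyond the scatter).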

Compound 3, half-maximal inhibitory concentration: 19000 nM
For compound 3 the middle estimate is 19-fold (1.28 log units) below the measured one, within the range that was stated.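

In this assay, a numeric value returns at the aromatic carbon between two ring nitrogen atoms when (2-chlorophenyl)amino replaces pyrrolidin-1-yl, giving an at least 5.2-fold lower number from compound 2 to compound 3 (0.72 log units; beyond the scatter). The reading for compound 2 is a limit, so this step is known only as a bound: the limit of > 100000 nM in this assay, at which 1 of the 3 values shown sits. Keeping a hydrogen-bond donor on the nitrogen does not by itself hold the number where compound 1 sits, as 2-chlorophenyl in place of 3-methoxypropyl on that nitrogen gives a 13-fold higher number from compound 1 to compound 3 (1.10 log units; beyond the scatter).

The compounds shown do not separate what the ether oxygen of the 3-methoxypropyl chain, the aromatic ring and the chlorine each contribute, and an unsubstituted phenylamino group or a plain propylamino chain would bear on that. As far as these compounds go, whether the hydrogen on the nitrogen itself matters also stays open, since pyrrolidin-1-yl differs from (3-methoxypropyl)amino in more than the donor, and a methyl group on the nitrogen of (3-methoxypropyl)amino would address that question more directly.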